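This account rests on a few compounds, and the source may have more. Where it says the series, first, only, none or still open, it means among the compounds named here.

For the measured compounds named here, compound 3, `O=c1ccoc2cc(OCc3cn(Cc4ccccc4F)nn3)ccc12`, is the one compound of the three whose result in a functional assay on A549 cells (Homo sapiens) for cytotoxicity, read by MTT assay, with a stated time of 48 h (a higher number here means a weaker inhibitor, a lower number a stronger inhibitor), is a number rather than a limit: in this assay compound 3 gives 10800 nM. Compound 1, `O=c1ccoc2cc(OCc3cn(Cc4ccc(Cl)cc4)nn3)ccc12`, reaches only the limit of this assay, > 100000 nM. Compound 2, `Cc1ccccc1Cn1cc(COc2ccc3c(=O)ccoc3c2)nn1`, likewise sits at a limit, > 100000 nM. Both limits are the same line, (the limit of > 100000 nM in this assay, at which 2 of the 3 values shown sit). The steps to compound 3 are therefore read as at least modest: an at least 9.2-fold lower number from compound 1 to compound 3 (0.96 log units; beyond the scatter) and an at least 9.2-fold lower number from compound 2 to compound 3 (0.96 log units; beyond the scatter), while the step that the two limits leave unreadable from compound 1 to compound 2 cannot be sized.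

Compound 4, `N#Cc1cccc(Cn2cc(COc3ccc4c(=O)ccoc4c3)nn2)c1`, differs from compound 3 by 3-cyanophenyl in place of 2-fluorophenyl on a saturated chain carbon bound to an aromatic nitrogen. Going by the values given here, no measured step replaces a 2-fluorophenyl with a 3-cyanophenyl, so none bears on it directly; the two steps that exist only show that compound 3 stands apart from compound 1 and compound 2, which both sit at the limit. Compound 4 is therefore expected to give a higher number, with the step of a 3.7-fold higher number from compound 3 to compound 4 (0.57 log units; beyond the scatter) estimated as at least modest, and the estimate for compound 4 is 40000 nM, between 9000 nM and 150000 nM.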

Compound 4, half-maximal inhibitory concentration: 14300 nM
The estimate for compound 4 lay 2.8-fold (0.45 log units) above the measured number; the range from low to high includes it.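

In this assay, a second group on the saturated chain carbon bound to an aromatic nitrogen now gives a number rather than a limit: replacing 2-fluorophenyl with 3-cyanophenyl gives a 1.3-fold higher number from compound 3 to compound 4 (0.12 log units; within the scatter). Compound 3 thus no longer stands alone, as compound 4 also separates from the two compounds at the limit, with an at least 6.9-fold lower number from compound 2 to compound 4 (0.84 log units; beyond the scatter) and an at least 6.9-fold lower number from compound 1 to compound 4 (0.84 log units; beyond the scatter). These last two steps give only a minimum size, and one limit lies at the end of both: the limit of > 100000 nM in this assay, at which 2 of the 4 values shown sit.

Because 2-fluorophenyl and 3-cyanophenyl differ in both substituent and ring position, the compounds shown leave open which of the two matters, if either does. They also leave open how a carboxylic acid or an amine on the phenyl ring, or a longer chain in place of the benzyl carbon, would read in this assay.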